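Stereochemistry Left Undefined in a Small Epoxyketone Series

The source may hold more compounds than are shown below. What is called first, only, known or untested is meant among the compounds shown, and "the series" means these compounds.

Measured compounds:
compound 1 `CC(C)CC(=O)[C@@H]1O[C@@]12C(=O)C=C(Cc1ccccc1)NC2=O`, > 100000 nM in a functional assay on HeLa cells (Homo sapiens) for cytotoxicity, read by WST assay, with a stated time of 48 h; on this read-out lower numbers stand for stronger inhibition and higher numbers for weaker inhibition
compound 2 `CC1=CC(=O)[C@@]2(O[C@H]2C(=O)CC(C)C)C(=O)N1`, "not determined" (no result reported)

Compound 1 `CC(C)CC(=O)[C@@H]1O[C@@]12C(=O)C=C(Cc1ccccc1)NC2=O` reaches only the limit of this assay, given as > 100000 nM; this is a limit, not a number. Compound 2 `CC1=CC(=O)[C@@]2(O[C@H]2C(=O)CC(C)C)C(=O)N1` carries no result in this assay, recorded as "not determined" (no result reported), so where compound 2 stands in this assay cannot be said from a number. Among the measured compounds shown here, the only value shown in this assay is that of compound 1, (the limit of > 100000 nM in this assay, at which 1 of the 2 values shown sits).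

Compound 3 `CC1=CC(=O)C2(OC2C(=O)CC(C)C)C(=O)N1` differs from compound 2 in this way: the two compounds have the same atoms and bonds; at least one stereo element is drawn with a configuration in one of them and without one in the other: 2 of 2 stereo elements differ; a stereocentre at a saturated ring carbon is drawn R in compound 2 and without a configuration in compound 3; a stereocentre at a saturated ring carbon is drawn R in compound 2 and without a configuration in compound 3. For the measured compounds named here, since no step between two measured compounds is known in this assay, and the atoms and bonds of compound 2 and compound 3 are the same, the expected step in this assay is none beyond the usual scatter, in either direction. With compound 1 sitting at the limit > 100000 nM, compound 3 is estimated at 80000 nM, within 10000 nM to 300000 nM.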

Compound 3, half-maximal inhibitory concentration: 40500 nM
Beside the measured number, compound 3's estimate is 2.0-fold (0.30 log units) above it; measured number inside the range.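

Among the compounds shown here, compound 2 has no result in this assay, so no step from it to compound 3 can be read. The compounds shown leave open whether the configuration at the two stereocentres, drawn in compound 2 and undefined in compound 3, has any bearing on this assay.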